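Two methyls on the saturated ring and a potency limit

The compounds below may be only part of what the source reports. "The series", "measured", "known", "first", "only" and "open" are said of these compounds alone.

Compound 1 `C[C@H]1Cc2cc(C(N)=O)cnc2N1`: > 10000 nM
Compound 2 `NC(=O)c1cnc2c(c1)CCN2`: 175 nM

Of the compounds shown here, two sharing one core have been measured in an assay on isolated protein for inhibition of Nicotinamide N-methyltransferase (Homo sapiens), read by luminescence, with a stated time of 20 min; on this read-out higher numbers stand for weaker inhibition and lower numbers for stronger inhibition. Compound 1 `C[C@H]1Cc2cc(C(N)=O)cnc2N1` is the methyl-bearing member. In this assay, as far as these compounds go, compound 1 gives only a limit, > 10000 nM, so its true number is unknown and sits at the limit of > 10000 nM in this assay, at which 1 of the 2 values shown sits. Compound 2 `NC(=O)c1cnc2c(c1)CCN2` carries a hydrogen where compound 1 carries the methyl, and in this assay compound 2 gives 175 nM. Going by the values given here, the single measured step is an at least 57-fold lower number from compound 1 to compound 2 (1.75 log units; beyond the scatter).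

Compound 3 `C[C@@H]1Nc2ncc(C(N)=O)cc2[C@H]1C` has not yet been measured. It differs from compound 1 by methyl in place of hydrogen on a saturated ring carbon. Among the compounds with values here, the only step that bears on this change runs the opposite way: taking a methyl off the saturated ring moved the number down strongly, as an at least 57-fold lower number from compound 1 to compound 2 (1.75 log units; beyond the scatter) shows. Adding a second methyl therefore is not expected to move compound 3 below the limit seen for compound 1, and no step beyond the scatter toward stronger inhibition is expected.

Compound 3 is thus estimated at 20000 nM, with a range of 5000 nM to 80000 nM. The step this implies for compound 3, a step that the limit leaves unreadable from compound 1 to compound 3, is expected to leave it at or beyond the limit of this assay.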

Compound 3, half-maximal inhibitory concentration: > 10000 nM
Compound 3: only a limit was reported; the forecaster's own chance of this, stated with the estimate: 80%; the middle value is on the limit's open side.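

In this assay compound 3 gives > 10000 nM, which is a limit and not a number. Compound 1 also gives only a limit, so no step from compound 1 to compound 3 can be read: the limit of > 10000 nM in this assay, at which 2 of the 3 values shown sit.

As far as these compounds go, the true numbers of compound 1 and compound 3 stay open, as does whether the added methyl changes inhibition at all.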